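The source may hold more compounds than are shown below. What is called first, only, known or untested is meant among the compounds shown, and "the series" means these compounds.

In a functional assay on NIH3T3 cells (Mus musculus) (a lower number here means that less compound is needed, a higher number that more compound is needed for the effect), compound 1 `Cn1cncc1C(OCc1ccc(C#N)cc1-c1ccccc1)c1ccc(C#N)cc1` gives 140 nM. Compound 2 `Cn1cncc1C(OCc1ccc(C#N)cc1C#Cc1ccc(-c2ccccc2)cc1)c1ccc(C#N)cc1`, which has an ethynyl link, shows > 0.1 nM, and this is a limit of the assay, not a number. Compound 3 `Cn1cncc1C(OCc1ccc(C#N)cc1-c1ccc(-c2ccccc2)cc1)c1ccc(C#N)cc1` shows < 0.1 nM, also only a limit, so it stands at a limit and has no exact value. Compound 4 `Cn1cncc1C(OCc1ccc(C#N)cc1C#Cc1ccc([N+](=O)[O-])cc1)c1ccc(C#N)cc1` differs from it at one place: 2-(4-nitrophenyl)ethynyl in place of 4-phenylphenyl on an aromatic carbon. Among the compounds with values here, the one measured step bearing on this change, phenyl in place of hydrogen on an aromatic carbon, was large: an at least 1400-fold lower number from compound 1 to compound 3 (3.14 log units; beyond the scatter). That phenyl leaves with the 4-phenylphenyl group, so a higher number in this assay is expected, beyond the scatter but smaller than that step. The expected change is an at least 20-fold higher number from compound 3 to compound 4 (1.30 log units; beyond the scatter). For compound 4 the estimate is 2 nM, with an expected range from 0.1 nM to 40 nM.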

Compound 4, half-maximal effective concentration: 36 nM
Compound 4: middle estimate off by 18-fold (1.26 log units), on the low side; the measured number falls inside the stated range.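

Putting 2-(4-nitrophenyl)ethynyl in place of 4-phenylphenyl gives an at least 360-fold higher number from compound 3 to compound 4 (2.55 log units; beyond the scatter) in this assay, so the large drop seen at this position does not come with every large group placed there. Measured against the plain phenyl, the same group gives a 3.9-fold lower number from compound 1 to compound 4 (0.59 log units; beyond the scatter), which keeps only a modest part of that drop. Compound 2 stands only at a limit of the assay, so its step to compound 4 cannot be read: the limit of > 0.1 nM in this assay, at which 1 of the 4 values shown sits.

From the compounds shown here alone, it stays open whether the ethynyl link or the nitro group sets this number. Going by these compounds, how an amine or a carboxylic acid in place of the nitro group would read at this position also stays open.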